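The source may hold more compounds than are shown below. What is called first, only, known or untested is meant among the compounds shown, and "the series" means these compounds.

Measured compounds:
compound 1, `CCC(=O)Nc1ccc(S(=O)(=O)Oc2ccccc2I)cc1`, 11000 nM
compound 2, `O=C(CCCl)Nc1ccc(S(=O)(=O)Oc2ccccc2I)cc1`, 12000 nM

Both values come from a functional assay on M21 cells (Homo sapiens) for antiproliferative activity, read by sulforhodamine B assay, with a stated time of 48 h; on this read-out higher numbers stand for weaker inhibition and lower numbers for stronger inhibition. On these two numbers compound 2 sits at the top, with compound 1 nearest: a 1.1-fold higher number from compound 1 to compound 2 (0.04 log units; within the scatter), so the two compounds are not separated on this read-out.

Compound 3, `O=C(CCCCl)Nc1ccc(S(=O)(=O)Oc2ccccc2I)cc1`, extends the chain of compound 2: chloromethyl in place of chloro on a saturated chain carbon, two bonds along the chain from a carbonyl carbon. For the measured compounds named here, the only measured step that touches this part of the molecule is the one from compound 1 to compound 2, a 1.1-fold higher number from compound 1 to compound 2 (0.04 log units; within the scatter), which shows that adding chloro at the same place left the number unchanged. Lengthening that chain by one carbon is a change of similar character, and nothing in the two measured compounds points to a shift in either direction. The step in this assay is therefore expected to stay within the scatter.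

For compound 3 the estimate in this assay is 12000 nM, range 5000 nM to 28000 nM, meaning an expected step of no change at the digits printed from compound 2 to compound 3 (within the scatter).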

Compound 3, half-maximal inhibitory concentration: 7200 nM
Estimate against measurement, compound 3: 1.7-fold (0.22 log units) above; measured number inside the range.
By their numbers in this assay, from the lowest: compounds 3, 1 and 2 (each within the scatter of the next).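

In this assay, going from (2-chloroethyl)carbonyl to (3-chloropropyl)carbonyl gives a 1.7-fold lower number from compound 2 to compound 3 (0.22 log units; within the scatter) and chloromethyl in place of hydrogen gives a 1.5-fold lower number from compound 1 to compound 3 (0.18 log units; within the scatter) at the same saturated chain carbon, two bonds along the chain from a carbonyl carbon. Hydrogen, chloro and chloromethyl at this place therefore remain unseparated on this read-out, so the flat picture now covers a longer chlorine-bearing chain as well as the addition of chloro. No evidence bears on this outcome.

As far as these compounds go, whether a longer chain ending in chlorine, or an amine or a carboxylic acid in place of the chlorine, would give a step beyond the scatter remains open. The shared core is constant across all three compounds, so they say nothing about changes outside this chain.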